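The source may hold more compounds than are shown below. What is called first, only, known or untested is meant among the compounds shown, and "the series" means these compounds.

Measured in a functional assay on HEK293 cells for antagonist activity at prostaglandin E2 receptor EP4 subtype (Homo sapiens), read by HTRF and cAMP accumulation, with a stated time of 20 min; a higher number here means a weaker inhibitor, a lower number a stronger inhibitor:
- compound 1, `Cc1ccc(N2CCCC(CO)C2)nc1C(=O)Nc1c(C)ccc(C(=O)O)c1C`: 14.2 nM
- compound 2, `Cc1ccc(N2CCC(O)CC2)nc1C(=O)Nc1c(C)ccc(C(=O)O)c1C`: 19.5 nM
- compound 3, `Cc1ccc(N2CCCC(CO)C2)nc1C(=O)Nc1c(C)cc(C(=O)O)cc1C`: 16.5 nM

All three numbers sit close together. Compound 3 falls among the other two, and the gap from it to compound 1 as well as the gap to compound 2 is within the scatter, so no ranking of the three is supported by the data.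

Compound 4, `Cc1ccc(N2CCC(C)(O)CC2)nc1C(=O)Nc1c(C)cc(C(=O)O)cc1C`, is not yet measured. It differs from compound 3 in one place: 4-hydroxy-4-methylpiperidin-1-yl in place of 3-(hydroxymethyl)piperidin-1-yl on an aromatic carbon.

Among the measured compounds shown here, the only measured step that bears on this change is the one from compound 1 to compound 2, where the same leaving group was replaced by a hydroxypiperidinyl ring; that step gave a 1.4-fold higher number from compound 1 to compound 2 (0.14 log units; within the scatter). As far as these compounds go, the incoming group of compound 4 carries the hydroxyl on a ring carbon that also bears a methyl, a variation not covered by any measured pair, so its effect is unknown. The expectation is therefore a step of about a 1.2-fold higher number from compound 3 to compound 4 (0.08 log units; within the scatter), that is, none beyond the scatter. Compound 4 is estimated at 20 nM, within a range from 9 nM to 45 nM.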

Compound 4, half-maximal inhibitory concentration: 39.8 nM
The estimate for compound 4 lay 2.0-fold (0.30 log units) below the measured number, and the stated range covers the measured number.
By their numbers in this assay, from the lowest: compounds 1, 3 and 2 (each within the scatter of the next); then compound 4.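

In this assay, the exchange on the aromatic carbon next to the ring nitrogen gives a 2.4-fold higher number from compound 3 to compound 4 (0.38 log units; beyond the scatter), the only step shown that lies beyond the scatter, whereas a 1.4-fold higher number from compound 1 to compound 2 (0.14 log units; within the scatter) stays within it. The two groups have the same atoms and the same counts of hydrogen-bond donors and acceptors, so at this position a different joining of those atoms is enough to move the number by a modest step. Nothing on hand bears on why the number moves.

The 4-hydroxypiperidin-1-yl group appears only on the core of compound 1, so the contribution of the added methyl cannot be separated from that of the moved hydroxyl. Also open, as far as these compounds go, is how this position responds to a piperidine carrying an amine in place of the hydroxyl, or to a longer hydroxyalkyl chain.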